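The source may hold more compounds than are shown below. What is called first, only, known or untested is meant among the compounds shown, and "the series" means these compounds.

Measured so far:
compound 1 `N#Cc1c(-c2ccco2)[n+]([O-])c2ccc(C3OCCO3)cc2[n+]1[O-]` gives 35700 nM in an ADME assay on MRC5 cells (Homo sapiens) for cytotoxicity, read by fluorescence, with a stated time of 24 h; a higher number here means a weaker inhibitor, a lower number a stronger inhibitor
compound 2 `COc1ccc(-c2c(C#N)[n+]([O-])c3cc(C4OCCO4)ccc3[n+]2[O-])cc1` gives 15000 nM

Compound 2 has the lower number of the two: the step of a 2.4-fold lower number from compound 1 to compound 2 (0.38 log units; beyond the scatter) is modest but beyond the scatter, so compound 2 is the stronger inhibitor of this pair. The next compound, compound 3 `Cc1ccc(-c2c(C#N)[n+]([O-])c3cc(C4OCCO4)ccc3[n+]2[O-])cc1`, has not yet been measured in this assay. It differs from compound 2 by methyl in place of methoxy on an aromatic carbon. For the measured compounds named here, no measured step involves this exchange; the only step on record, placing 4-methoxyphenyl where furan-2-yl stood, touches a different part of the molecule and gives no guide to trading methoxy for methyl. With nothing in the data to push the number either way, compound 3 is expected to show a step of no change at the digits printed from compound 2 to compound 3 (within the scatter), that is, no change beyond the scatter. The estimate for compound 3 is 15000 nM, with a likely range from 7000 nM to 35000 nM.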

Compound 3, half-maximal inhibitory concentration in the MRC5 assay: 17200 nM
The estimate for compound 3 lay 1.1-fold (0.06 log units) below the measured number, and the stated range covers the measured number.
By their numbers in the MRC5 assay, from the lowest: compounds 2 and 3 (each within the scatter of the next); then compound 1.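

In the MRC5 assay, this position on the six-membered aromatic ring accepts the loss of the methoxy oxygen without a clear shift: compound 2 gives 15000 nM and compound 3 gives 17200 nM and a 1.1-fold higher number from compound 2 to compound 3 (0.06 log units; within the scatter) is a change from methoxy to methyl that cannot be told apart from repeat-measurement noise. The advantage over the furan-2-yl compound also remains with 4-methylphenyl, as a 2.1-fold lower number from compound 1 to compound 3 (0.32 log units; beyond the scatter) shows, so this modest gain does not depend on the methoxy oxygen. In a physicochemical assay for lipophilicity, read by HPLC, measured as octanol-water partition (a higher number here means a more lipophilic compound, a lower number a more polar compound), compound 2 gives 1.4 and compound 3 gives 1.6 and the same exchange gives a number 0.20 log units higher from compound 2 to compound 3 (within the scatter), so the two compounds are not separated by this measure either.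

Nothing at hand explains these numbers. Methoxy and methyl are both small groups, so it remains open whether an amine, a carboxylic acid or a longer chain at this position would move the number in the MRC5 assay.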